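Nitro replacing pyrrolidinyl amine on the chalcone-type side

A few compounds are considered here, and "the series" means these few. Any claim that something is new, unique, unknown or untested is made for them only; others in the source may bear on it.

Going by the values given here, compound 2 `COc1ccc(C(=O)/C=C/c2ccc(N3CCCC3)cc2)c2c1C=CC(C)(C)O2` gives the highest of the two numbers measured so far in a functional assay on HepG2 cells (Homo sapiens) for antiproliferative activity, read by MTT assay, with a stated time of 24 h (on this read-out lower numbers stand for stronger inhibition and higher numbers for weaker inhibition), namely 4740 nM; compound 1 `COc1ccc(C(=O)/C=C/c2ccc(N(C)C)cc2)c2c1C=CC(C)(C)O2` gives 730 nM in this assay, and the only measured step, a 6.5-fold higher number from compound 1 to compound 2 (0.81 log units; beyond the scatter), separates them. Compound 3 `COc1ccc(C(=O)/C=C/c2ccc([N+](=O)[O-])cc2)c2c1C=CC(C)(C)O2` differs from compound 2 by nitro in place of pyrrolidin-1-yl on an aromatic carbon. Among the compounds with values here, no measured step concerns a nitro group or the loss of an amine; the one step available, from a dimethylamino to a pyrrolidin-1-yl group, exchanges one amine for another and does not bear on this change directly. The expectation for compound 3 in this assay therefore rests on compound 2 alone and is a step of a 1.3-fold higher number from compound 2 to compound 3 (0.10 log units; within the scatter), with wide uncertainty in either direction. Compound 3 is estimated at 6000 nM in this assay, within a range from 1500 nM to 25000 nM.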

Compound 3, half-maximal inhibitory concentration: 2610 nM
Compound 3: middle estimate off by 2.3-fold (0.36 log units), on the high side, and the stated range covers the measured number.
By their numbers in this assay, from the lowest: compound 1; then compounds 3 and 2 (each within the scatter of the next).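

In this assay the nitro group, which carries no amine, cannot be told apart from pyrrolidin-1-yl at this position on the aromatic ring: the step of a 1.8-fold lower number from compound 2 to compound 3 (0.26 log units; within the scatter) stays within the scatter. Dimethylamino stands apart from both groups, and the step of a 3.6-fold higher number from compound 1 to compound 3 (0.55 log units; beyond the scatter) lies beyond the scatter, so the presence of an amine does not by itself track the numbers here: compound 2 carries an amine and still groups with compound 3, not with compound 1. Nothing at hand bears on why the three groups fall this way.

Open, from the compounds shown here alone, is whether smaller amines, such as a primary amino or methylamino group, or a larger one, such as diethylamino, stay close to compound 1. Also open, going by these compounds, is where a morpholin-4-yl group or a plain hydrogen at this place would fall.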